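Lipophilicity notes on a diaryl ether quinazolinone series

The source may hold more compounds than are shown below. What is called first, only, known or untested is meant among the compounds shown, and "the series" means these compounds.

Measured so far in a physicochemical assay for lipophilicity, in phosphate buffer, measured as octanol-water partition; on this read-out lower numbers stand for lower lipophilicity and higher numbers for higher lipophilicity:
compound 1, `Cc1nc2ccccc2c(=O)n1/N=C/c1ccc(Oc2ccc([N+](=O)[O-])cc2)cc1`: 4.01
compound 2, `Cc1nc2ccccc2c(=O)n1/N=C/c1ccc(Oc2ccc(Br)cc2)cc1`: 4.64
compound 3, `Cc1nc2ccccc2c(=O)n1/N=C/c1ccc(Oc2ccc(F)cc2)cc1`: 4.21

Compound 3 stands second highest of the three numbers in this assay; its gap to compound 1 is within the scatter, while a number 0.43 log units lower from compound 2 to compound 3 (beyond the scatter) lies beyond it. The unmeasured compound 4, `Cc1cc(Oc2ccc(/C=N/n3c(C)nc4ccccc4c3=O)cc2)ccc1Cl`, differs from compound 3 as 4-chloro-3-methylphenyl in place of 4-fluorophenyl on an oxygen on an aromatic ring. Among the compounds with values here, the steps that bear on this are the halogen swaps among the measured compounds: a number 0.63 log units higher from compound 1 to compound 2 (beyond the scatter), a number 0.20 log units higher from compound 1 to compound 3 (within the scatter) and a number 0.43 log units lower from compound 2 to compound 3 (beyond the scatter). Going from fluoro to a heavier halogen raised the number beyond the scatter, and here a methyl enters as well. A modest upward step is therefore expected, a number 0.79 log units higher from compound 3 to compound 4 (beyond the scatter), so compound 4 is estimated at 5, with a range from 4.6 to 5.4.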

Compound 4, partition coefficient: 4.41
The estimate for compound 4 lay 0.59 log units above the measured number; the measured number lies below the stated range.
By their numbers in this assay, from the lowest: compounds 1, 3, 4 and 2 (each within the scatter of the next, the first and the last beyond it).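

In this assay the 4-chloro-3-methylphenyl group gives a number 0.20 log units higher from compound 3 to compound 4 (within the scatter) against 4-fluorophenyl and a number 0.23 log units lower from compound 2 to compound 4 (within the scatter) against 4-bromophenyl, so at this position it is not separated from either. Against 4-nitrophenyl the same group gives a number 0.40 log units higher from compound 1 to compound 4 (beyond the scatter) and stands apart only there. No measured evidence accounts for this result. The compounds shown leave open what the chloro and the methyl each contribute alone, since they enter together here. From the compounds shown here alone, how an amine or a carboxylic acid on this ring would read also stays open.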